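Aryl variation on the triazole of a bromoquinoline series

The source may hold more compounds than are shown below. What is called first, only, known or untested is meant among the compounds shown, and "the series" means these compounds.

Working notes. In an ADME assay on PANC-1 cells (Homo sapiens) for cytotoxicity, read by sulforhodamine B assay, with a stated time of 48 h, tested at 10 uM (a higher number here means more inhibition at the concentration tested (going by the name of the read-out), a lower number less inhibition), compound 1 `CCCc1cn(C(c2ccccc2)c2cc3cc(Br)ccc3nc2OC)nn1` gives 11.3% and compound 2 `COc1nc2ccc(Br)cc2cc1C(c1ccccc1)n1cc(-c2ccccc2C(F)(F)F)nn1` gives 11.4%. Going by the values given here, compound 2 is one of only two measured compounds, and its number sits within the scatter of compound 1: the step of a number 0.1 percentage points higher from compound 1 to compound 2 (within the scatter) is flat despite the exchange of propyl for 2-(trifluoromethyl)phenyl on an aromatic carbon. Compound 3 `COc1nc2ccc(Br)cc2cc1C(c1ccccc1)n1cc(-c2ccc(F)cc2)nn1` follows from compound 2 by the change (4-fluorophenyl in place of 2-(trifluoromethyl)phenyl on an aromatic carbon). Among the compounds with values here, no measured step exchanges one aryl group for another at this position, so the single flat step from compound 1 to compound 2 is the only guide, and it suggests that substitution at this carbon does not move the read-out in this assay beyond the scatter. The step of a number 0.4 percentage points lower from compound 2 to compound 3 (within the scatter) is therefore expected to stay within the scatter. For compound 3 the expected value in this assay is 11%, with an estimated range from 0% to 25%.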

Compound 3, a percentage reported as inhibition, at one concentration (the size of the read-out at that concentration, not a potency): 14.9%
For compound 3 the middle estimate is 3.9 percentage points below the measured one, within the range that was stated.
By their numbers in this assay, from the lowest: compounds 1, 2 and 3 (each within the scatter of the next).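

In this assay, going by these compounds alone, an exchange of one aryl group for another at this carbon of the five-membered aromatic ring can now be read for the first time: 4-fluorophenyl in place of 2-(trifluoromethyl)phenyl gives a number 3.5 percentage points higher from compound 2 to compound 3 (within the scatter) and so leaves the read-out flat. The exchange of propyl for 4-fluorophenyl, a number 3.6 percentage points higher from compound 1 to compound 3 (within the scatter) as well, agrees with this, so propyl, 2-(trifluoromethyl)phenyl and 4-fluorophenyl at this carbon all lie within the scatter of one another. Nothing available bears on this result.

Still open, as far as these compounds go, is whether an amine, a carboxylic acid or a longer alkyl chain at this carbon would give a step beyond the scatter. Also open, from the compounds shown here alone, is whether any change on the shared core, away from this carbon, would move the number in this assay at all.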